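The source may report more compounds than this note shows. Statements on the series, on what has been measured and on what is new or still open speak of the compounds shown alone.

Measured compounds in the series:

compound 1, `COc1ccc2c(c1)OC(COc1ccc(CCC(=O)O)c(F)c1)CC2`: 58%
compound 2, `O=C(O)CCc1ccc(OCC2COc3cc(Br)ccc3O2)cc1F`: 67%
compound 3, `CCOC(CC(=O)O)c1ccc(OCC2COc3ccc(Cl)cc3O2)cc1`: 46%

In a functional assay on HEK293 cells for agonist activity at Free fatty acid receptor 1 (Homo sapiens), read by fluorescence and calcium flux, with a stated time of 10 min (a higher number here means a larger maximal response, a lower number a smaller maximal response), compound 3 stands lowest of the three values. Compound 1 lies nearest, its number beyond the scatter above that of compound 3; compound 2 lies furthest, also beyond the scatter above it.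

Compound 4, `Cn1nncc1C(CC(=O)O)c1ccc(OCC2COc3ccc(Cl)cc3O2)cc1`, has not been measured. It differs from compound 3 in one place: 1-methyl-1H-1,2,3-triazol-5-yl in place of ethoxy on a saturated chain carbon bound to an aromatic carbon and a saturated chain carbon. For the measured compounds named here, no pair of measured compounds differs in this way, so there is no measured step to lean on. The expectation for this assay is a step of no more than the usual scatter, leaning slightly upward if anything. For compound 4 the expected step is a number 6 percentage points higher from compound 3 to compound 4 (within the scatter). Compound 4 is thus estimated at 52%, within 30% to 78%.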

Compound 4, largest response reached (Emax), in percent of the reference or control that the assay uses: 70%
Estimate against measurement, compound 4: 18 percentage points below; the measured number falls inside the stated range.
By their numbers in this assay, from the lowest: compound 3; then compounds 1, 2 and 4 (each within the scatter of the next, the first and the last beyond it).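

In this assay, the saturated chain carbon bound to an aromatic carbon and a saturated chain carbon proves sensitive to the group it carries: 1-methyl-1H-1,2,3-triazol-5-yl in place of ethoxy gives a number 24 percentage points higher from compound 3 to compound 4 (beyond the scatter). Ethoxy is therefore not needed there for the maximal response, and a five-membered aromatic ring is accepted at this carbon. Nothing available explains this step.

This single step cannot separate the ring itself from its nitrogens. On these data alone, a phenyl ring or a longer alkoxy chain such as propoxy on the same carbon remains open.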